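Oxamate esters: replacing benzyloxy with ethoxycarbonyl

The source may hold more compounds than are shown below. What is called first, only, known or untested is meant among the compounds shown, and "the series" means these compounds.

Compound 1 `CCOC(=O)C(=O)Nc1nc(-c2cc(Br)no2)cs1` gives 12 mg/kg as its value
Compound 2 `CCOCCOC(=O)C(=O)Nc1nc(-c2cc(OCc3ccccc3)no2)cs1` gives 3.7 mg/kg as its value
Compound 3 `O=C(Nc1nc(-c2cc(-c3c(F)cccc3Cl)no2)cs1)C(=O)OCc1ccccc1` gives > 30 mg/kg as a limit

The three compounds were tested in a functional assay on the whole organism with Rattus norvegicus as the target (on this read-out lower numbers stand for an effect already at smaller amounts and higher numbers for an effect only at larger amounts of compound), and compound 2 has the lowest number at 3.7 mg/kg in that read-out. Its nearest neighbour is compound 1 at 12 mg/kg and the gap between them lies beyond the usual scatter. Compound 3 has no number in this assay because its > 30 mg/kg is a limit of the assay.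

The next compound is compound 4 `CCOCCOC(=O)C(=O)Nc1nc(-c2cc(C(=O)OCC)no2)cs1` which carries ethoxycarbonyl in place of benzyloxy on an aromatic carbon and the change sits next to the ring nitrogen. Among the compounds with values here, no measured pair isolates such a change, so there is no direct guide to its size. Compound 2 already stands lowest at 3.7 mg/kg so a replacement is expected to land higher rather than lower. The expected change is a 2.2-fold higher number from compound 2 to compound 4 (0.33 log units; beyond the scatter) as a modest rise in the number. In this assay the estimate for compound 4 is 8 mg/kg with a range of 2.5 mg/kg to 25 mg/kg expected.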

Compound 4, dose for half-maximal effect: 0.08 mg/kg
For compound 4 the middle estimate is 100-fold (2.00 log units) above the measured one; measured number below the stated range.
By their numbers in this assay, from the lowest: compound 4; then compound 2; then compound 1. At a limit, above all of these: compound 3.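

In this assay the exchange of benzyloxy for ethoxycarbonyl gives a 46-fold lower number from compound 2 to compound 4 (1.67 log units; beyond the scatter). Within the data shown here, this is the first reading of a single change, and it shows that the group on this aromatic carbon of the five-membered aromatic ring, next to the ring nitrogen, can by itself shift the dose by a wide margin while the rest of the molecule stays the same. Compound 1, compound 2 and compound 3 differ from one another in more than one place, so they could not show this.

Nothing in the data at hand accounts for the size of this step. As far as these compounds go, it remains open whether a similar drop in the number would be seen with a carboxylic acid, an amide or a nitrile on the same carbon.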